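Alkynyl for vinyl on a branched-sugar cytidine and uridine pair

This account rests on a few compounds, and the source may have more. Where it says the series, first, only, none or still open, it means among the compounds named here.

Measured compounds: compound 1 `C=C[C@@]1(O)[C@@H](CO)O[C@@H](n2ccc(N)nc2=O)[C@@H]1O` gives 60800 nM; compound 2 `CC#C[C@@]1(O)[C@@H](CO)O[C@@H](n2ccc(N)nc2=O)[C@@H]1O` gives 24500 nM; compound 3 `C=C[C@@]1(O)[C@@H](CO)O[C@@H](n2ccc(=O)[nH]c2=O)[C@@H]1O` gives 148000 nM, all in a functional assay on L1210 cells (Mus musculus), read by MTT assay; on this read-out higher numbers stand for weaker inhibition and lower numbers for stronger inhibition.

Compound 2 differs from compound 1 by prop-1-yn-1-yl in place of vinyl on a saturated ring carbon, and that change gave a 2.5-fold lower number from compound 1 to compound 2 (0.39 log units; beyond the scatter). The difference between the core of compound 1 and the core of compound 3 is not broken down here; compound 3 stands at the highest of the three numbers. Compound 4 `CC#C[C@@]1(O)[C@@H](CO)O[C@@H](n2ccc(=O)[nH]c2=O)[C@@H]1O`, not yet measured, differs from compound 3 by prop-1-yn-1-yl in place of vinyl on a saturated ring carbon, the same kind of change as from compound 1 to compound 2, at a place described in the same words. On that one earlier step alone, compound 4 is expected to show a step of about a 2.5-fold lower number from compound 3 to compound 4 (0.39 log units; beyond the scatter) in this assay, since the change from compound 1 to compound 2 gave a 2.5-fold lower number from compound 1 to compound 2 (0.39 log units; beyond the scatter). Compound 4 is estimated at 60000 nM, with a range from 30000 nM to 120000 nM.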

Compound 4, half-maximal inhibitory concentration: 354000 nM
For compound 4 the middle estimate is 5.9-fold (0.77 log units) below the measured one; the whole stated range lies below it.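

In this assay, prop-1-yn-1-yl in place of vinyl on a saturated ring carbon gave a 2.4-fold higher number from compound 3 to compound 4 (0.38 log units; beyond the scatter), so the step did not carry over from the core of compound 1 to the core of compound 3, and the two steps ran in opposite directions: the same change on two cores in this assay, a 2.5-fold lower number (0.39 log units; beyond the scatter) from compound 1 to compound 2 and a 2.4-fold higher number (0.38 log units; beyond the scatter) from compound 3 to compound 4, 5.9-fold (0.77 log units) apart, beyond the scatter of two such steps In this series, then, the outcome of this change depended on the core it was made on. Going by these compounds alone, with only two pairs, this does not show why the steps differ, nor which way the change would go on any further core. The compounds shown leave open how a longer chain, such as but-1-yn-1-yl, would behave at the same ring carbon on either core. They also leave open whether an amine on that carbon would follow either step.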